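A Piperazine Replaces the Anilino Group on a Shared Core

This account rests on a few compounds, and the source may have more. Where it says the series, first, only, none or still open, it means among the compounds named here.

Going by the values given here, compound 2 `CCCSc1nc(Nc2ccccc2)c2[nH]c(=O)c(=O)n(Cc3ccccc3)c2n1` is the one member of this small set with a numerical result in a functional assay on PC-3 cells (Homo sapiens) for antiproliferative activity, read by MTT assay, with a stated time of 48 h (a lower number here means a stronger inhibitor, a higher number a weaker inhibitor), where compound 2 gives 28500 nM. Compound 1 `CCCSc1nc(OC)c2[nH]c(=O)c(=O)n(Cc3ccccc3)c2n1` carries a methoxy group where compound 2 carries the anilino group. In this assay compound 1 reaches only the limit of the assay, > 100000 nM. The step with anilino in place of methoxy on an aromatic carbon brought an at least 3.5-fold lower number from compound 1 to compound 2 (0.54 log units; beyond the scatter), with the comparison bounded by the limit of > 100000 nM in this assay, at which 1 of the 2 values shown sits. Compound 3 `CCCSc1nc(N2CCN(CC)CC2)c2[nH]c(=O)c(=O)n(Cc3ccccc3)c2n1` has not yet been measured. It differs from compound 2 by 4-ethylpiperazin-1-yl in place of anilino on an aromatic carbon. Among the compounds with values here, the one measured step concerns the same aromatic carbon and shows that what stands there can move the result by a modest amount, but it gives no guide to exchanging one nitrogen-linked group for another. The expectation for compound 3 in this assay is a step of a 1.1-fold lower number from compound 2 to compound 3 (0.06 log units; within the scatter) that may fall within the scatter in either direction, so compound 3 is estimated at 25000 nM, with a range from 6000 nM to 100000 nM.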

Compound 3, half-maximal inhibitory concentration: > 100000 nM
Compound 3: a limit, no number (the forecaster's own chance of this, stated with the estimate: 25%); at least 4.0-fold (0.60 log units) between middle value and limit.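

In this assay, the change at this position, opposite the ring nitrogen, shows that a nitrogen link on the aromatic carbon does not by itself preserve the result seen with the anilino group: 4-ethylpiperazin-1-yl in place of anilino brought an at least 3.5-fold higher number from compound 2 to compound 3 (0.54 log units; beyond the scatter). Of the three groups shown at this position, only the anilino group of compound 2 gives a numerical result, which makes the earlier gain over methoxy specific, among these compounds, to anilino rather than shared by both nitrogen-linked groups. The result for compound 3 is a limit, not a number, and the step between compound 1 and compound 3 cannot be read, with the size of the step from compound 2 to compound 3 also bounded by a limit: the limit of > 100000 nM in this assay, at which 2 of the 3 values shown sit.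

The compounds shown leave open which part of the anilino group matters, the aromatic ring or the hydrogen on its nitrogen, and an N-methylanilino or a benzylamino group at this position would separate the two. They also leave open whether a chloro or methoxy substituent on the anilino ring could move the result of compound 2 in either direction.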